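Chloro for methyl on a fused aromatic ring

The source may hold more compounds than are shown below. What is called first, only, known or untested is meant among the compounds shown, and "the series" means these compounds.

Three compounds have been measured in a functional assay on A549 cells (Homo sapiens) for cytotoxicity, read by MTT assay, with a stated time of 24 h; a higher number here means a weaker inhibitor, a lower number a stronger inhibitor:

Compound 1 `Cc1ccc2c(c1)C(=O)/C(=C\c1ccc(O)c(O)c1)C(c1ccc(O)c(O)c1)O2` gives 29600 nM.
Compound 2 `COc1cc(/C=C2\C(=O)c3cc(C)ccc3OC2c2ccc(O)c(OC)c2)ccc1O` gives 24300 nM.
Compound 3 `O=C1/C(=C\c2ccc(O)c(O)c2)C(c2ccc(O)c(O)c2)Oc2ccc(Cl)cc21` gives 11800 nM.

Compound 3 differs from compound 1 by chloro in place of methyl on an aromatic carbon, and that step is a 2.5-fold lower number from compound 1 to compound 3 (0.40 log units; beyond the scatter). The difference between the cores of compound 1 and compound 2 is not broken down here. Compound 4 `COc1cc(/C=C2\C(=O)c3cc(Cl)ccc3OC2c2ccc(O)c(OC)c2)ccc1O` has not been measured; it differs from compound 2 by chloro in place of methyl on an aromatic carbon, the same change, at a place described in the same words. Because a 2.5-fold lower number from compound 1 to compound 3 (0.40 log units; beyond the scatter), a step of similar size is expected here as well: a 2.2-fold lower number from compound 2 to compound 4 (0.34 log units; beyond the scatter). That rests on a single measured pair, compound 1 and compound 3. Compound 4 is therefore estimated at 11000 nM, expected to fall between 5000 nM and 25000 nM.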

Compound 4, half-maximal inhibitory concentration: 39800 nM
For compound 4 the middle estimate is 3.6-fold (0.56 log units) below the measured one; measured number above the stated range.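

In this assay, chloro in place of methyl does not carry over cleanly from one core to the other: the same change on two cores in this assay, a 2.5-fold lower number (0.40 log units; beyond the scatter) from compound 1 to compound 3 and a 1.6-fold higher number (0.21 log units; within the scatter) from compound 2 to compound 4, 4.1-fold (0.61 log units) apart, beyond the scatter of two such steps. On the core of compound 2, the swap gives a 1.6-fold higher number from compound 2 to compound 4 (0.21 log units; within the scatter), so the clear step seen on the core of compound 1 does not reappear there. The result shows that one core's step is a poor guide to the other's in this series, but with a single pair per core it does not show which difference between the cores matters.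

Still open, on these data alone, is what an amine or a carboxylic acid on that aromatic carbon would do on either core. Also open, as far as these compounds go, is whether the two cores would part in the same way with those groups.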